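The compounds below may be only part of what the source reports. "The series", "measured", "known", "first", "only" and "open" are said of these compounds alone.

Compound 2 `COc1cc(-c2nn(-c3cccc(NC(=O)Nc4ccc(Cl)c(C(F)(F)F)c4)c3)cc2-c2ccncc2)ccc1Cl` joins the shared core through a urea to a (4-chloro-3-(trifluoromethyl)phenyl)amino group. Going by the values given here, in a functional assay on SK-MEL-2 cells (Homo sapiens) for inhibition, read by sulforhodamine B assay, with a stated time of 48 h (a higher number here means a weaker inhibitor of growth, a lower number a stronger inhibitor of growth), compound 2 gives 1010 nM and is one of only two compounds measured so far. The other, compound 1 `COc1cc(-c2nn(-c3cccc(NC(=O)c4ccc(Cl)c(C(F)(F)F)c4)c3)cc2-c2ccncc2)ccc1Cl`, gives 1900 nM in this assay, and the step of a 1.9-fold lower number from compound 1 to compound 2 (0.27 log units; within the scatter) shows that placing the same aryl directly on the carbonyl or through an amino group makes no difference that the measurement can resolve. Compound 3 `COc1cc(-c2nn(-c3cccc(NC(=O)c4ccccc4)c3)cc2-c2ccncc2)ccc1Cl` has not yet been measured. It differs from compound 2 by phenyl in place of (4-chloro-3-(trifluoromethyl)phenyl)amino on a carbonyl carbon, so both the amino link and the chloro and trifluoromethyl substituents are removed, leaving a plain benzamide. Among the compounds with values here, the single measured step concerns the link alone and was small; no measured step speaks to the loss of the two substituents, which is the larger part of this change. A step toward a weaker inhibitor, a 5.0-fold higher number from compound 2 to compound 3 (0.69 log units; beyond the scatter), is therefore expected, with wide uncertainty. Compound 3 is estimated at 5000 nM, within 1500 nM to 20000 nM.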

Compound 3, concentration for 50% growth inhibition: 389 nM
The estimate for compound 3 lay 13-fold (1.11 log units) above the measured number, outside the stated range (below it).
By their numbers in this assay, from the lowest: compound 3; then compounds 2 and 1 (each within the scatter of the next).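

Removing the chloro and trifluoromethyl substituents did not weaken growth inhibition, as the opening estimate assumed, but strengthened it. In this assay the cleanest reading is a 4.9-fold lower number from compound 1 to compound 3 (0.69 log units; beyond the scatter) with the amide link unchanged, and the change that also removes the amino link gives a 2.6-fold lower number from compound 2 to compound 3 (0.41 log units; beyond the scatter) in the same direction. Among these three compounds, then, the 4-chloro-3-(trifluoromethyl)phenyl group is not needed for activity at this position, and a bare phenyl on the carbonyl carbon gives the strongest inhibitor, although nothing available explains why the smaller group does better.

The two substituents leave together in these compounds, so it remains open which of them accounts for the step, and a phenyl carrying only a chloro or only a trifluoromethyl would separate the two. Also open, as far as these compounds go, is whether a urea link to a plain phenyl would match the benzamide, and whether something other than an aromatic ring on the carbonyl carbon, such as a short alkyl chain or a cyclic amine like morpholine, would lower the number further.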